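Substituent at the amide-bearing chain carbon and oral tail flick

A few compounds are considered here, and "the series" means these few. Any claim that something is new, unique, unknown or untested is made for them only; others in the source may bear on it.

Measured compounds:
- compound 1 `C[C@H](NC(=O)CN(c1nc(Cl)nc2[nH]cnc12)C1CC1)C(=O)OCc1ccccc1` gives 36.1% in a functional assay on the whole organism (Tail, strain ICR) with Mus musculus as the target, in the tail flick test, with a stated time of 120 min, at a dose of 25 umol/kg by the oral route; a higher number here means a stronger effect of the compound at the dose given, a lower number a weaker effect
- compound 2 `O=C(CN(c1nc(Cl)nc2[nH]cnc12)C1CC1)NCC(=O)OCc1ccccc1` gives 21.7% in this assay
- compound 3 `O=C(OCc1ccccc1)[C@@H]1CCCN1C(=O)CN(c1nc(Cl)nc2[nH]cnc12)C1CC1` gives 38.4% in this assay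

Compound 2 stands lowest of the three numbers. Its nearest neighbour is compound 1, reached through the step of a number 14.4 percentage points lower from compound 1 to compound 2 (beyond the scatter), which took the number down beyond the scatter when hydrogen replaced methyl. For the measured compounds named here, compound 3 gives a higher number than compound 2 as well, further off than compound 1, though no single-point step connects those two.

Compound 4 `C[C@@H](O)[C@H](NC(=O)CN(c1nc(Cl)nc2[nH]cnc12)C1CC1)C(=O)OCc1ccccc1` differs from compound 2 by 1-hydroxyethyl in place of hydrogen on a saturated chain carbon bound to an amide-type nitrogen and a carbonyl carbon. Going by the values given here, the one measured step that bears on the same place is a number 14.4 percentage points lower from compound 1 to compound 2 (beyond the scatter): removing a methyl there lowered the read-out modestly. Putting a 1-hydroxyethyl group back on that carbon is expected to move the number the other way, by a step of about the same size as the methyl-to-hydrogen step, so a number 13.3 percentage points higher from compound 2 to compound 4 (beyond the scatter) is estimated. On that basis compound 4 is expected to give 35% in this assay, with a range from 20% to 50%.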

Compound 4, a percentage reported as activity, at one dose (the size of the read-out at that dose, not a potency): 30.7%
Compound 4: the middle estimate sits 4.3 percentage points above what was measured, and the stated range covers the measured number.
By their numbers in this assay, from the lowest: compounds 2, 4, 1 and 3 (each within the scatter of the next, the first and the last beyond it).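

Both a number 9 percentage points higher from compound 2 to compound 4 (within the scatter) and a number 5.4 percentage points lower from compound 1 to compound 4 (within the scatter) are within the scatter, so 1-hydroxyethyl on this carbon cannot be told apart from hydrogen or from methyl in this assay. Of the steps at this carbon, only a number 14.4 percentage points lower from compound 1 to compound 2 (beyond the scatter) is beyond the scatter. A group of 3 heavy atoms carrying a hydroxyl is therefore accommodated here at the dose given, but the series shows no graded dependence on the size of the substituent. No measurement on hand accounts for these numbers.

An isopropyl group on the same carbon would show whether the hydroxyl of 1-hydroxyethyl matters or only its carbon chain. The compounds shown also leave open how an amine, a carboxylic acid or a longer chain at this carbon would read out.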